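The compounds below may be only part of what the source reports. "The series", "measured", "known", "first", "only" and "open" are said of these compounds alone.

Compound 1 `C[C@@H](NC(=O)Nc1ccccc1F)c1ccccc1` and compound 2 `C[C@@H](NC(=O)Nc1cccc(F)c1)c1ccccc1` share one core and differ only in where a fluoro sits. In an ADME assay on the whole organism with Oryza sativa as the target, tested at 10 uM (on this read-out lower numbers stand for a stronger effect and higher numbers for a weaker effect at the one concentration tested), compound 1 gives 77%, and compound 2 gives 84%. Compound 2 thus holds the larger of the two figures, but its gap to compound 1 lies within the usual scatter, so the pair reads as alike. Compound 3 `C[C@@H](NC(=O)Nc1cccc(F)c1F)c1ccccc1` is not yet measured; it differs from compound 2 by fluoro in place of hydrogen on an aromatic carbon. For the measured compounds named here, no measured step of this kind exists here, so a change no larger than the scatter is expected. The step from compound 2 to compound 3 is expected to be a number 2 percentage points lower from compound 2 to compound 3 (within the scatter). Compound 3 is estimated at 82%, between 65% and 95%.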

Compound 3, a percentage reported as activity, at one concentration (the size of the read-out at that concentration, not a potency): 90%
Beside the measured number, compound 3's estimate is 8 percentage points below it; the range from low to high includes it.
By their numbers in this assay, from the lowest: compounds 1, 2 and 3 (each within the scatter of the next, the first and the last beyond it).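

In this assay, fluoro in place of hydrogen on this aromatic carbon, ortho to a fluoro group, gives a number 6 percentage points higher from compound 2 to compound 3 (within the scatter), so this single change shows no clear effect. The same kind of change gives a number 13 percentage points higher from compound 1 to compound 3 (beyond the scatter), the first modest gap in this set to clear the scatter. No accompanying measurement offers an explanation for either step. Open, as far as these compounds go, is whether a chloro or methyl group on this same carbon would move the read-out further, and whether a hydroxyl group would reverse its direction.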